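Compound 2 to compound 3: one aryl group exchanged

A few compounds are considered here, and "the series" means these few. Any claim that something is new, unique, unknown or untested is made for them only; others in the source may bear on it.

In a functional assay on NCI-H520 cells (Homo sapiens) for cytotoxicity (a higher number here means a weaker inhibitor of growth, a lower number a stronger inhibitor of growth), compound 1 (`COc1ccc(C2=C(c3ccc(SC)cc3)CC3CCCN3C2=O)cc1OC(=O)C1CCCN1C(=O)OC(C)(C)C`) gives 5000 nM and compound 2 (`COc1ccc(C2=C(c3ccc(SC)cc3)CC3CCCN3C2=O)cc1Br`) gives 700 nM as the lower of the two numbers, with a gap between them that lies beyond the scatter. Compound 2 therefore marks the stronger end of the little that has been measured so far.

The next compound, compound 3 (`CSc1ccc(C2=C(c3ccc(F)c(C)c3)C(=O)N3CCCC3C2)cc1`), keeps the 4-(methylsulfanyl)phenyl group and the shared core. It carries 4-fluoro-3-methylphenyl in place of 3-bromo-4-methoxyphenyl on a double-bonded ring carbon.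

Going by the values given here, no pair of measured compounds differs in one place only, so the series offers no direct guide to the size of this step. The only spread available runs from compound 2 at 700 nM to compound 1 at 5000 nM and gives a rough frame for the expectation. The expected step is a 2.1-fold higher number from compound 2 to compound 3 (0.33 log units; beyond the scatter) in the direction of a higher number, though a result within the scatter would not surprise. For compound 3 the estimate is 1500 nM with an expected range from 400 nM to 5000 nM in this assay.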

Compound 3, concentration for 50% growth inhibition: 500 nM
Compound 3: the middle estimate sits 3.0-fold (0.48 log units) above what was measured, within the range that was stated.
By their numbers in this assay, from the lowest: compounds 3 and 2 (each within the scatter of the next); then compound 1.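

In this assay, going by these compounds alone, the exchange of 3-bromo-4-methoxyphenyl for 4-fluoro-3-methylphenyl on a double-bonded ring carbon gives a 1.4-fold lower number from compound 2 to compound 3 (0.15 log units; within the scatter) and provides the first single-place comparison. At this position, with the 4-(methylsulfanyl)phenyl group and the shared core held constant, the two aryl groups cannot be told apart in this read-out, even though the bromine and the methoxy group leave and the entering group has 0 hydrogen-bond acceptors. Neither the bromine nor the methoxy group is therefore needed for growth inhibition at this level in this pair, and no measured property is available to explain the result.

The compounds shown leave open how far this tolerance extends, since both groups compared here are substituted phenyl rings; a phenyl ring bearing a carboxylic acid or an aminomethyl group, or a cyclohexyl ring in place of the aryl group, would test it more severely. They also leave open whether the 4-(methylsulfanyl)phenyl group matters, as it stays the same throughout, and a replacement such as 4-methoxyphenyl or an unsubstituted phenyl ring would address that question.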